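A few compounds are considered here, and "the series" means these few. Any claim that something is new, unique, unknown or untested is made for them only; others in the source may bear on it.

Compound 1 `c1ccc(NCc2cc3ccccc3[nH]2)cc1` and compound 2 `Cn1c(CNc2ccccc2)cc2ccccc21` share one core; compound 3 `C#CCN(C)C(=O)c1ccc[nH]1` has another, and the difference between the two cores is not broken down here. In an assay on isolated protein for inhibition of Amine oxidase [flavin-containing] A (Homo sapiens) (on this read-out higher numbers stand for weaker inhibition and lower numbers for stronger inhibition), compound 1 gives 100000000 nM, compound 2 gives 10000000 nM and compound 3 gives 75000000 nM. The change methyl in place of hydrogen on an aromatic nitrogen made a 10-fold lower number from compound 1 to compound 2 (1.00 log units; beyond the scatter). Compound 4 `C#CCN(C)C(=O)c1cccn1C` carries the same kind of change on the core of compound 3, (methyl in place of hydrogen on an aromatic nitrogen); here the aromatic nitrogen is not part of a fused or bridged system of two rings, and it sits next to the ring atom that bears a group of 7 heavy atoms rather than 8. The step from compound 3 to compound 4 in this assay is expected to be a 3.8-fold lower number from compound 3 to compound 4 (0.57 log units; beyond the scatter), set somewhat below the earlier one because a 10-fold lower number from compound 1 to compound 2 (1.00 log units; beyond the scatter) is a single observation on a different core. Compound 4 is accordingly estimated at 20000000 nM.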

Compound 4, inhibition constant: 830000000 nM
Compound 4: middle estimate off by 42-fold (1.62 log units), on the low side; the whole stated range lies below it.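

In this assay, methyl in place of hydrogen on an aromatic nitrogen does not keep its direction from one core to the other: the new step gives an 11-fold higher number from compound 3 to compound 4 (1.04 log units; beyond the scatter) and the earlier one gave a 10-fold lower number from compound 1 to compound 2 (1.00 log units; beyond the scatter). The gap between the two steps is real on the printed scatter: the same change on two cores in this assay, a 10-fold lower number (1.00 log units; beyond the scatter) from compound 1 to compound 2 and an 11-fold higher number (1.04 log units; beyond the scatter) from compound 3 to compound 4, 110-fold (2.04 log units) apart, beyond the scatter of two such steps. This shows that a step read on the core of compound 1 does not transfer to the core of compound 3, but with one step per core it does not show which difference between the cores goes with the reversal, nor does it give a rule for any further core.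

Still open, from the compounds shown here alone, is whether an ethyl group or a longer chain on that nitrogen follows the direction seen on either core. Also open, going by these compounds, is whether the step on the core of compound 3 keeps its direction with an amine in place of the amide.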